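The compounds below may be only part of what the source reports. "The series", "measured", "known", "first", "only" and "open" are said of these compounds alone.

Compound 2 `COc1cccc(Oc2cccc(CN3CCC(n4cc(C)c(=O)[nH]c4=O)CC3)c2)c1` and compound 1 `Cc1cn(C2CCN(Cc3cccc(Oc4ccc(Cl)cc4)c3)CC2)c(=O)[nH]c1=O` share one core and differ only in the aryl group on the ether oxygen. In an ADME assay on MRC5 cells (Homo sapiens) for cytotoxicity, read by fluorescence and resazurin assay, with a stated time of 3 days (a higher number here means a weaker inhibitor, a lower number a stronger inhibitor), compound 2 gives 25300 nM, and compound 1 gives 25100 nM; the step of a 1.0-fold higher number from compound 1 to compound 2 (0.00 log units; within the scatter) places the two within the scatter of each other. Compound 3 `Cc1cn(C2CCN(Cc3cccc(Oc4ccc(Cl)c(C(F)(F)F)c4)c3)CC2)c(=O)[nH]c1=O` carries a further change at the same place: 4-chloro-3-(trifluoromethyl)phenyl in place of 3-methoxyphenyl on an oxygen on an aromatic ring. Going by the values given here, the only comparable step, from compound 1 to compound 2, was flat, so the author expects no step beyond the scatter in this assay and estimates compound 3 at 22000 nM, within 8000 nM to 60000 nM, a step of a 1.2-fold lower number from compound 2 to compound 3 (0.06 log units; within the scatter).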

Compound 3, half-maximal inhibitory concentration: 5280 nM
Estimate against measurement, compound 3: 4.2-fold (0.62 log units) above; measured number below the stated range.
By their numbers in this assay, from the lowest: compound 3; then compounds 1 and 2 (each within the scatter of the next).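

In this assay the aryl group on the ether oxygen does matter: a 4.8-fold lower number from compound 2 to compound 3 (0.68 log units; beyond the scatter) is a change the earlier flat pair did not show. Trifluoromethyl in place of hydrogen on an aromatic carbon gives a 4.8-fold lower number from compound 1 to compound 3 (0.68 log units; beyond the scatter) while the rest of compound 1 stays the same, so this single addition is enough to carry a step beyond the scatter. Nothing given here explains the step. As far as these compounds go, whether a nitrile or a methyl in place of that trifluoromethyl would give a similar step remains open, as does whether trifluoromethyl would act alike on the 3-methoxyphenyl group.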